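Notes on a ring methyl stereocentre

The compounds below may be only part of what the source reports. "The series", "measured", "known", "first", "only" and "open" are said of these compounds alone.

Measured in an ADME assay on microsomes from liver (Rattus norvegicus) for metabolic stability, read by LC-MS, using NADPH, with stated times of 6 min and 10 min, tested at 0.5 uM; on this read-out higher numbers stand for a more stable compound and lower numbers for a less stable compound:
- compound 1 `CC(=O)N1CCN(c2cc(-c3cc(Cl)c4c(N)ncnn34)ccc2C(C)O)C(=O)C1(C)C`: 100%
- compound 2 `CC(=O)N1CCN(c2cc(-c3cc(Cl)c4c(N)ncnn34)ccc2C#N)C(=O)C1(C)C`: 89%
- compound 3 `CC(=O)N1C[C@@H](C)N(c2cc(-c3cc(Cl)c4c(N)ncnn34)ccc2C#N)C(=O)C1(C)C`: 59%

Compound 3 has the lowest of the three numbers in this assay, at 59%, and its gaps to both other compounds are beyond the scatter. The next compound is compound 4 `CC(=O)N1C[C@H](C)N(c2cc(-c3cc(Cl)c4c(N)ncnn34)ccc2C#N)C(=O)C1(C)C`, and the change is the two compounds have the same atoms and bonds and differ only in configuration as drawn: 1 of 1 stereo elements differ; a stereocentre at a saturated ring carbon is drawn R in compound 3 and S in compound 4.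

Going by the values given here, no measured step swaps a configuration, so the evidence is indirect. The closest step is a number 30 percentage points lower from compound 2 to compound 3 (beyond the scatter), modest in size, with methyl in place of hydrogen on a saturated ring carbon. It shows that this carbon can matter, but only for one drawn configuration. The step of a number 11 percentage points lower from compound 1 to compound 2 (beyond the scatter), cyano in place of 1-hydroxyethyl on an aromatic carbon, is elsewhere in the structure and has little bearing here.

Compound 2, at 89%, serves as a rough upper reference. A small upward move that stays within the scatter is expected, as a number 7 percentage points higher from compound 3 to compound 4 (within the scatter). The estimate for compound 4 is 66%, with an expected range from 42% to 90%.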

Compound 4, percent of the compound remaining: 94%
Compound 4: the middle estimate sits 28 percentage points below what was measured; measured number outside the range, above it.
By their numbers in this assay, from the lowest: compound 3; then compounds 2, 4 and 1 (each within the scatter of the next, the first and the last beyond it).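

Configuration at this saturated ring carbon, not the presence of the methyl alone, decides the result in this assay: the read-out gives a number 35 percentage points higher from compound 3 to compound 4 (beyond the scatter). The S-drawn methyl shows no loss against the unmethylated nitrile, with methyl in place of hydrogen on a saturated ring carbon giving a number 5 percentage points higher from compound 2 to compound 4 (within the scatter), so the earlier drop belongs to the R drawing rather than to methyl substitution in general. The gap can be assigned to this single stereocentre because nothing else separates the pair: the fact that compounds 3 and 4 differ only in the configuration as drawn.

The compounds shown leave open whether an ethyl, a hydroxymethyl or an aminomethyl group at this carbon would show the same dependence on configuration. Also open, on these data alone, is whether the gap between the two drawings persists with 1-hydroxyethyl in place of the nitrile.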